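Aryl variation on the shared core: outlook for compound 4

The source may hold more compounds than are shown below. What is called first, only, known or untested is meant among the compounds shown, and "the series" means these compounds.

Compound 1 `COc1ccc(-c2cn3ccnc3c(-c3ccc4ncn(C5CCCCC5)c4c3)n2)cc1`, compound 2 `O=Cc1ccc(-c2cn3ccnc3c(-c3ccc4ncn(C5CCCCC5)c4c3)n2)cc1` and compound 3 `c1ccc2c(-c3cn4ccnc4c(-c4ccc5ncn(C6CCCCC6)c5c4)n3)cccc2c1` share one core and differ only in the aryl group attached to it. In a functional assay on MDA-MB-231 cells (Homo sapiens) for inhibition, read by sulforhodamine B assay, with a stated time of 48 h, tested at 10 uM (on this read-out lower numbers stand for less inhibition and higher numbers for more inhibition at the one concentration tested (going by the name of the read-out)), compound 1 gives 71.1%, compound 2 gives 51.2% and compound 3 gives 20.8%. Compound 2 thus stands second highest of the three, between compound 1 above it and compound 3 below it, with both gaps beyond the scatter.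

The next compound, compound 4 `Fc1ccccc1-c1cn2ccnc2c(-c2ccc3ncn(C4CCCCC4)c3c2)n1`, keeps the core of compound 2 and changes the aryl group: 2-fluorophenyl in place of 4-formylphenyl on an aromatic carbon.

Among the measured compounds shown here, two measured steps bear on this. Exchanging one substituent on the phenyl ring for another gave a number 19.9 percentage points lower from compound 1 to compound 2 (beyond the scatter). Replacing the whole 4-formylphenyl by naphthalen-1-yl gave a number 30.4 percentage points lower from compound 2 to compound 3 (beyond the scatter), and the related exchange gave a number 50.3 percentage points lower from compound 1 to compound 3 (beyond the scatter). For the measured compounds named here, the change to compound 4 keeps a single phenyl ring and only alters its substituent, so a step of the smaller kind is expected rather than the larger one; no measured compound carries fluorine, so the direction is open. Compound 4 is expected to give about 50% in this assay, within 25% to 75%. This corresponds to an expected step of a number 1.2 percentage points lower from compound 2 to compound 4 (within the scatter).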

Compound 4, a percentage reported as inhibition, at one concentration (the size of the read-out at that concentration, not a potency): 21.3%
Compound 4: middle estimate off by 28.7 percentage points, on the high side; measured number below the stated range.
By their numbers in this assay, from the lowest: compounds 3 and 4 (each within the scatter of the next); then compound 2; then compound 1.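

Keeping a single phenyl ring on the shared core does not preserve the number in this assay: exchanging the substituted phenyl gives a number 29.9 percentage points lower from compound 2 to compound 4 (beyond the scatter) and, against the top compound of the series, a number 49.8 percentage points lower from compound 1 to compound 4 (beyond the scatter) on this aromatic carbon next to the ring nitrogen. The 2-fluorophenyl group also sits level with the larger naphthalen-1-yl group, with a number 0.5 percentage points higher from compound 3 to compound 4 (within the scatter) lying within the scatter, so among these four compounds the size of the aryl group does not separate the lower pair from the higher pair; the two higher numbers belong to the 4-methoxyphenyl and 4-formylphenyl compounds, and none of the four goes against that split. No evidence is at hand on why the number falls with this exchange.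

The compounds shown leave open whether the low number of compound 4 goes with the fluorine itself or with where it stands on the phenyl ring, a question that a 4-fluorophenyl group would address. They also leave open how a phenyl ring carrying an amine or a carboxylic acid would compare with the 4-methoxyphenyl group of compound 1.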